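The source may hold more compounds than are shown below. What is called first, only, known or untested is meant among the compounds shown, and "the series" means these compounds.

Compound 1 `COc1ncc(-c2ccc3nc(NC(=O)N4CCCC4)nn3c2)cc1NS(=O)(=O)c1ccc(F)cc1`: 1690 nM
Compound 2 `COc1ncc(-c2ccc3nc(NC(=O)NCCN4CCCC4)nn3c2)cc1NS(=O)(=O)c1ccc(F)cc1`: 1120 nM

In a functional assay on U-87MG ATCC cells for cytotoxicity against U-87 MG (Homo sapiens), read by MTT assay, with a stated time of 72 h (a lower number here means a stronger inhibitor, a higher number a weaker inhibitor), compound 2 gives 1120 nM and so sits within the usual scatter of compound 1. Compound 3 `COc1ncc(-c2ccc3nc(NC(=O)NCCN4CCCCC4)nn3c2)cc1NS(=O)(=O)c1ccc(F)cc1` keeps the rest of compound 2 but carries piperidin-1-yl in place of pyrrolidin-1-yl on a saturated chain carbon, two bonds along the chain from an amide-type nitrogen on a saturated chain carbon. Among the measured compounds shown here, only one measured step bears on this change: a 1.5-fold lower number from compound 1 to compound 2 (0.18 log units; within the scatter) came from swapping a different group and stayed within the scatter. The step expected here is therefore small, a 1.1-fold higher number from compound 2 to compound 3 (0.03 log units; within the scatter) with no clear direction and nothing beyond the scatter. Compound 3 is estimated at 1200 nM with a range from 600 nM to 2400 nM expected to hold the measurement.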

Compound 3, half-maximal inhibitory concentration: 1080 nM
Estimate against measurement, compound 3: 1.1-fold (0.05 log units) above; low and high end bracket the measured number.
By their numbers in this assay, from the lowest: compounds 3, 2 and 1 (each within the scatter of the next).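

In this assay, the place on the saturated chain carbon, two bonds along the chain from an amide-type nitrogen, takes piperidin-1-yl as well as pyrrolidin-1-yl, with a 1.0-fold lower number from compound 2 to compound 3 (0.02 log units; within the scatter). Set against pyrrolidin-1-yl on the carbonyl carbon, (2-(piperidin-1-yl)ethyl)amino gives a 1.6-fold lower number from compound 1 to compound 3 (0.19 log units; within the scatter), so these three compounds stay level. From the compounds shown here alone, whether morpholin-4-yl, dimethylamino or a longer chain at this place would move the number beyond the scatter remains open. Nothing available here offers an explanation for these numbers.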